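Furan-2-yl in place of 3-nitrophenyl

This account rests on a few compounds, and the source may have more. Where it says the series, first, only, none or still open, it means among the compounds named here.

In a functional assay on MDA-MB-231 cells (Homo sapiens) for antiproliferative activity, read by MTT assay, with a stated time of 72 h (a higher number here means a weaker inhibitor, a lower number a stronger inhibitor), compound 1 `CC1=CC[C@H]2[C@H](CC[C@]2(C)O)C(C)(C)[C@@H]1CC[C@H]1[C@]2(C)CC[C@H](OC(=O)c3ccccc3)C(C)(C)O[C@H]2CC[C@@]1(C)O` gives 16100 nM, compound 2 `CC1=CC[C@H]2[C@H](CC[C@]2(C)O)C(C)(C)[C@@H]1CC[C@H]1[C@]2(C)CC[C@H](OC(=O)c3ccc(C(F)(F)F)cc3)C(C)(C)O[C@H]2CC[C@@]1(C)O` gives 19500 nM and compound 3 `CC1=CC[C@H]2[C@H](CC[C@]2(C)O)C(C)(C)[C@@H]1CC[C@H]1[C@]2(C)CC[C@H](OC(=O)c3cccc([N+](=O)[O-])c3)C(C)(C)O[C@H]2CC[C@@]1(C)O` gives 34700 nM. Compound 3 stands at the weak end of this narrow range: the data show a 1.8-fold higher number from compound 2 to compound 3 (0.25 log units; within the scatter) and a 2.2-fold higher number from compound 1 to compound 3 (0.33 log units; beyond the scatter). Compound 4 `CC1=CC[C@H]2[C@H](CC[C@]2(C)O)C(C)(C)[C@@H]1CC[C@H]1[C@]2(C)CC[C@H](OC(=O)c3ccco3)C(C)(C)O[C@H]2CC[C@@]1(C)O` carries furan-2-yl in place of 3-nitrophenyl on a carbonyl carbon. Going by the values given here, no measured compound has furan-2-yl, so only the small steps among the aromatic rings bear on it, such as a 1.2-fold higher number from compound 1 to compound 2 (0.08 log units; within the scatter). A small move towards compound 1 at 16100 nM is expected in this assay, close to the scatter. The expected change is a 1.7-fold lower number from compound 3 to compound 4 (0.24 log units; within the scatter). For compound 4 the estimate is 20000 nM, with an expected range of 9000 nM to 42000 nM.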

Compound 4, half-maximal inhibitory concentration: 14000 nM
Compound 4: middle estimate off by 1.4-fold (0.15 log units), on the high side, and the stated range covers the measured number.
By their numbers in this assay, from the lowest: compounds 4, 1, 2 and 3 (each within the scatter of the next, the first and the last beyond it).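

In this assay, the position on the carbonyl carbon accepts a five-membered aromatic ring with 1 hetero atom: with a 1.2-fold lower number from compound 1 to compound 4 (0.06 log units; within the scatter) and a 1.4-fold lower number from compound 2 to compound 4 (0.14 log units; within the scatter) as the steps, furan-2-yl cannot be told apart from phenyl or 4-(trifluoromethyl)phenyl. Only the replacement of 3-nitrophenyl reaches beyond the scatter, with a 2.5-fold lower number from compound 3 to compound 4 (0.39 log units; beyond the scatter) and all four compounds still in one narrow band. No measurement at hand accounts for this step.

Still open, from the compounds shown here alone, is whether an amine or a carboxylic acid on the aromatic ring, or a longer chain in its place, moves the number out of this band.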